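A few compounds are considered here, and "the series" means these few. Any claim that something is new, unique, unknown or untested is made for them only; others in the source may bear on it.

Compound 2 `COc1ccccc1N1CCN(CC2=NS(=O)(=O)c3ccc(C)cc3N2)CC1` stands at the top of the two measured numbers: in a functional assay on spleen for antagonist activity at Alpha-1B adrenergic receptor (Rattus norvegicus) (on this read-out lower numbers stand for lower potency and higher numbers for higher potency (the scale is a negative logarithm)), compound 2 gives 6.05, while compound 1 `COc1ccccc1N1CCN(CC2=NS(=O)(=O)c3ccccc3N2)CC1` gives 5.46, the climb being a number 0.59 log units higher from compound 1 to compound 2 (beyond the scatter). Compound 3 `COc1ccccc1N1CCN(CC2=NS(=O)(=O)c3ccc(Cl)cc3N2)CC1` differs from compound 2 by chloro in place of methyl on an aromatic carbon. Within the data shown here, no measured step covers an exchange of methyl for chloro; the only step known, a number 0.59 log units higher from compound 1 to compound 2 (beyond the scatter), shows that occupying this aromatic carbon raised potency, so a similar-sized group is expected to leave this assay largely unchanged. The step expected is a number 0.05 log units higher from compound 2 to compound 3 (within the scatter). Compound 3 is therefore estimated at 6.1, within 5.6 to 6.6.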

Compound 3, negative logarithm of the antagonist equilibrium constant: 6.17
Beside the measured number, compound 3's estimate is 0.07 log units below it, and the stated range covers the measured number.
By their numbers in this assay, from the lowest: compound 1; then compounds 2 and 3 (each within the scatter of the next).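

Chloro and methyl on this aromatic carbon are not told apart in this assay, the step being a number 0.12 log units higher from compound 2 to compound 3 (within the scatter). Chloro in place of hydrogen also gives a gain, a number 0.71 log units higher from compound 1 to compound 3 (beyond the scatter), so the rise seen earlier is not confined to methyl but holds for both groups placed here. Nothing measured here explains why these two groups give such close numbers.

Still open, going by these compounds, is how an amine, a methoxy group or a carboxylic acid on this carbon would fare. On these data alone, it also remains open whether chloro or methyl on the other aromatic carbons of this ring would give a similar gain.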